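The source may report more compounds than this note shows. Statements on the series, on what has been measured and on what is new or still open speak of the compounds shown alone.

Measured compounds in the series:

- compound 1, `O=C1N=C(N2N=C(c3ccccc3)CC2c2ccccc2O)S/C1=C1/C(=O)Nc2ccccc21`, 36600 nM
- compound 2, `O=C1N=C(N2N=C(c3ccccc3)CC2c2ccccc2O)S/C1=C1/C(=O)Nc2ccc(Br)cc21`, 940 nM
- compound 3, `COc1ccc(C2=NN(C3=NC(=O)/C(=C4\C(=O)Nc5ccccc54)S3)C(c3ccc(OC)cc3)C2)cc1`, 100000 nM

All three values come from a functional assay on cells (Cancer cell lines, Homo sapiens) for cytotoxicity, read by sulforhodamine B assay, with a stated time of 48 h; a higher number here means a weaker inhibitor of growth, a lower number a stronger inhibitor of growth. Compound 1 gives 36600 nM in this assay, and compound 2 gives 940 nM. The two differ by one change, (bromo in place of hydrogen on an aromatic carbon), and that change made a large step: a 39-fold lower number from compound 1 to compound 2 (1.59 log units; beyond the scatter). Compound 3 carries a different core; how the core of compound 3 differs from the core of compound 1 is not broken down here. Compound 3 stands at the high end of the three numbers in this assay, with compound 1 nearer to it and compound 2 far below it.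

Compound 4, `COc1ccc(C2=NN(C3=NC(=O)/C(=C4\C(=O)Nc5ccc(Br)cc54)S3)C(c3ccc(OC)cc3)C2)cc1`, is not yet measured. It relates to compound 3 as compound 2 relates to compound 1: the change is bromo in place of hydrogen on an aromatic carbon, at a place described in the same words as for the pair of compound 1 and compound 2, so it is the same change made on the other core.

Within the data shown here, whether the step repeats on the core of compound 3 is unknown; only one example of the change exists among the measured compounds. Still, a step of comparable direction is expected, a 25-fold lower number from compound 3 to compound 4 (1.40 log units; beyond the scatter), because compound 1 and compound 2 show a 39-fold lower number from compound 1 to compound 2 (1.59 log units; beyond the scatter). The weaker starting point of compound 3 leaves room for a smaller step than that one, so the expectation is widened. Compound 4 is estimated at 4000 nM in this assay, with a range from 1000 nM to 30000 nM.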

Compound 4, concentration for total growth inhibition: 32500 nM
Compound 4: the middle estimate sits 8.1-fold (0.91 log units) below what was measured; measured number above the stated range.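

In this assay, bromo in place of hydrogen on an aromatic carbon lowers the number on both cores, and on the core of compound 3 the change gives a 3.1-fold lower number from compound 3 to compound 4 (0.49 log units; beyond the scatter). Among these compounds, the direction of the change therefore carries over from one core to the other, but its size does not: the same change on two cores in this assay, a 39-fold lower number (1.59 log units; beyond the scatter) from compound 1 to compound 2 and a 3.1-fold lower number (0.49 log units; beyond the scatter) from compound 3 to compound 4, 13-fold (1.10 log units) apart, beyond the scatter of two such steps This rests on only two pairs of compounds, so it shows that the size of the step cannot be assumed to transfer between these cores, but it does not show which feature of the cores goes with the smaller step, nor why the two steps differ.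

The compounds shown leave open whether chloro, fluoro, a methoxy group, an amine or a carboxylic acid on the same aromatic carbon would also respond differently on the two cores, or whether this difference is particular to bromo. They also leave open how the step would behave on a core that carries a methoxy group on only one of its two outer benzene rings, which would help separate the contributions of those two rings.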